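This account rests on a few compounds, and the source may have more. Where it says the series, first, only, none or still open, it means among the compounds named here.

Measured so far:
Compound 1, `CNCc1cn(S(=O)(=O)c2ccc(F)cn2)c(-c2cccnc2F)c1F`, gives 87% in a functional assay on the whole organism (strain Jcl:Sprague-Dawley) for inhibition, with Rattus norvegicus as the target, with stated times of 3 min and 3 h, at a dose of 1 mg/kg by the intravenous route; a lower number here means less inhibition, a higher number more inhibition at the dose given (going by the name of the read-out).
Compound 2, `CNCc1cn(S(=O)(=O)c2cccnc2Cl)c(-c2cccnc2F)c1F`, has "not determined" (no result reported) in this assay.

Among the compounds with values here, compound 1 shows strong inhibition in this assay, and it is the only compound with a number. Compound 2 shares the core of compound 1 and differs from it only in the ring on the sulfonyl sulfur, but for compound 2 no number exists in this assay, so where it stands cannot be said from the data. Compound 3, `CNCc1cn(S(=O)(=O)c2cnccc2C)c(-c2cccnc2F)c1F`, is reached from compound 2 by one change: 4-methylpyridin-3-yl in place of 2-chloropyridin-3-yl on a sulfonyl sulfur. Within the data shown here, since no step between measured compounds is available, the size and direction of the change from compound 2 to compound 3 cannot be derived; the only anchor is compound 1 with 87% in this assay, which suggests this series inhibits strongly. Compound 3 is therefore expected to give about 75% in this assay, with a likely range from 40% to 95%.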

Compound 3, a percentage reported as inhibition, in the whole organism at one dose (the size of the read-out at that dose, not a potency): 98%
Compound 3: the middle estimate sits 23 percentage points below what was measured; measured number outside the range, above it.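

In this assay the group on the sulfonyl sulfur can now be seen to affect the result: with the rest of the molecule unchanged, 4-methylpyridin-3-yl in place of 5-fluoropyridin-2-yl gives a number 11 percentage points higher from compound 1 to compound 3 (beyond the scatter) as a modest step. As far as these compounds go, the step from compound 2 to compound 3 cannot be read, as compound 2 has no number, so the standing of 2-chloropyridin-3-yl at this place stays unknown. Nothing measured here explains the difference between compound 1 and compound 3.

These two compounds differ in both the substituent and how the ring is attached, so neither can be credited separately with the step. Also open, from the compounds shown here alone, is how a methoxy group or an amine on the pyridine ring, or a simple propyl chain in place of the ring, would fare on the sulfonyl sulfur.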